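Amine substitution on the shared core: compound 4

The source may hold more compounds than are shown below. What is called first, only, known or untested is meant among the compounds shown, and "the series" means these compounds.

The shared core carries an amine on an aromatic carbon, and compound 1 `CCC(CC)Nc1nc(C)nc2c(-c3ccc(OC)nc3C)c(C)nn12`, compound 2 `CCCCC(C)Nc1nc(C)nc2c(-c3ccc(OC)nc3C)c(C)nn12` and compound 3 `CCCC(C)Nc1nc(C)nc2c(-c3ccc(OC)nc3C)c(C)nn12` differ only in the alkyl group on that nitrogen. In an assay on cell membranes for displacement of a labelled ligand from corticotropin-releasing factor receptor 1 (Rattus norvegicus) (on this read-out lower numbers stand for stronger inhibition and higher numbers for weaker inhibition), compound 1 gives 3.1 nM, compound 2 gives 5.1 nM and compound 3 gives 3.5 nM. Compound 3 stands second highest of the three numbers, nearest compound 1 and furthest compound 2; every step among the three is within the scatter, including a 1.6-fold higher number from compound 1 to compound 2 (0.22 log units; within the scatter).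

Compound 4 `CCCCN(CC)c1nc(C)nc2c(-c3ccc(OC)nc3C)c(C)nn12` carries butyl(ethyl)amino in place of (1-methylbutyl)amino on an aromatic carbon. Among the compounds with values here, two measured steps bear on it, a 1.1-fold higher number from compound 1 to compound 3 (0.05 log units; within the scatter) and a 1.5-fold lower number from compound 2 to compound 3 (0.16 log units; within the scatter), each reshaping the alkyl on the nitrogen without moving the number beyond the scatter. Within the data shown here, no measured step removes the hydrogen-bond donor, and that part of the change has no precedent here. The expected step is a modest move to a higher number, a 2.3-fold higher number from compound 3 to compound 4 (0.36 log units; beyond the scatter), held with a wide range. Compound 4 is expected to give 8 nM, between 2 nM and 40 nM.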

Compound 4, half-maximal inhibitory concentration: 4.9 nM
Estimate against measurement, compound 4: 1.6-fold (0.21 log units) above; low and high end bracket the measured number.
By their numbers in this assay, from the lowest: compounds 1, 3, 4 and 2 (each within the scatter of the next).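

Compound 4 is the only one of the four without the hydrogen-bond donor on the amine nitrogen, yet in this assay the steps of a 1.4-fold higher number from compound 3 to compound 4 (0.15 log units; within the scatter) and a 1.0-fold lower number from compound 2 to compound 4 (0.02 log units; within the scatter) and a 1.6-fold higher number from compound 1 to compound 4 (0.20 log units; within the scatter) all lie within the scatter. Across these compounds, then, that nitrogen hydrogen can be lost, and a single branched alkyl can give way to butyl plus ethyl, with no readable change in the number. No supporting data bear on why this exchange leaves the number within the scatter.

With compound 4 alone lacking the donor, the loss of that hydrogen cannot be separated from the change in the alkyl groups. Also open, going by these compounds, is whether this position accepts a pyrrolidine ring on the nitrogen, or a chain ending in a hydroxyl group or a carboxylic acid.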